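Moving the hydroxy group on the aryl ring of compound 1

A few compounds are considered here, and "the series" means these few. Any claim that something is new, unique, unknown or untested is made for them only; others in the source may bear on it.

compound 1 `COc1cc(N2C(N)=C(C#N)C(c3ccccc3O)C3=C2CC(C)(C)CC3=O)cc(OC)c1OC` — 10%
compound 2 `COc1cc(N2C(N)=C(C#N)C(c3cccc([N+](=O)[O-])c3)C3=C2CC(C)(C)CC3=O)cc(OC)c1OC` — 30%
compound 3 `COc1cc(N2C(N)=C(C#N)C(c3ccccc3Cl)C3=C2CC(C)(C)CC3=O)cc(OC)c1OC` — 20%

In a functional assay on Ehrlich cells (Mus musculus) for cytotoxicity, tested at 100 ug/mL (a lower number here means a weaker effect, a higher number a stronger effect of the compound at the concentration tested), compound 1 stands at the lowest of the three numbers shown, although its gap to compound 3 is within the scatter; the step of a number 20 percentage points higher from compound 1 to compound 2 (beyond the scatter) is the only one beyond it, while the step of a number 10 percentage points higher from compound 1 to compound 3 (within the scatter) is not. Compound 4 `COc1cc(N2C(N)=C(C#N)C(c3ccc(O)cc3)C3=C2CC(C)(C)CC3=O)cc(OC)c1OC` differs from compound 1 in one place: 4-hydroxyphenyl in place of 2-hydroxyphenyl on a saturated ring carbon. Within the data shown here, no measured step moves the hydroxy group around its ring, so the nearest guides are the replacement of that group in the step of a number 10 percentage points higher from compound 1 to compound 3 (within the scatter) and the exchange of the whole aryl group in the step of a number 20 percentage points higher from compound 1 to compound 2 (beyond the scatter). Because the step of a number 10 percentage points higher from compound 1 to compound 3 (within the scatter) stayed within the scatter, the step of a number 5 percentage points higher from compound 1 to compound 4 (within the scatter) is expected to be small, at most a slight rise. The value of compound 4 in this assay is estimated at 15%, with a range from 5% to 30%.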

Compound 4, a percentage reported as activity, at one concentration (the size of the read-out at that concentration, not a potency): 100%
Compound 4: middle estimate off by 85 percentage points, on the low side; the measured number lies above the stated range.
By their numbers in this assay, from the lowest: compounds 1, 3 and 2 (each within the scatter of the next, the first and the last beyond it); then compound 4.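

In this assay, the same hydroxy group on the same aryl ring gives a number 90 percentage points higher from compound 1 to compound 4 (beyond the scatter), so with the atoms unchanged, where the hydroxy group sits on the ring matters far more at this saturated ring carbon than the earlier exchanges suggested. The 4-hydroxyphenyl group also stands well clear of the other two aryl groups, with a number 80 percentage points higher from compound 3 to compound 4 (beyond the scatter) and a number 70 percentage points higher from compound 2 to compound 4 (beyond the scatter). No evidence here explains this jump.

Still open, going by these compounds, is whether a 3-hydroxyphenyl, 4-methoxyphenyl or 4-aminophenyl group on the same carbon would give a similar number. A reading at one concentration also leaves the potency of compound 4 unknown.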